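The source may report more compounds than this note shows. Statements on the series, on what has been measured and on what is new or still open speak of the compounds shown alone.

Compound 2 `CC#CC(CC(=O)O)c1ccc(OCc2ccc(C(=O)N3CCN(Cc4ccccc4)CC3)s2)cc1` carries a benzyl group on the amine nitrogen in the ring. In a functional assay on HEK293 cells for agonist activity at Free fatty acid receptor 1 (Homo sapiens), read by fluorescence and calcium flux (on this read-out higher numbers stand for an effect only at larger amounts of compound and lower numbers for an effect already at smaller amounts), compound 2 gives 155 nM. For the measured compounds named here, its only measured neighbour is compound 1 `CC#CC(CC(=O)O)c1ccc(OCc2ccc(C(=O)N3CCN(c4ccccc4)CC3)s2)cc1`, which bears a phenyl on that same nitrogen; in this assay compound 1 gives 72 nM. The single measured step, a 2.2-fold higher number from compound 1 to compound 2 (0.33 log units; beyond the scatter), places compound 2 highest of the two numbers shown.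

Compound 3 `CC#CC(CC(=O)O)c1ccc(OCc2ccc(C(=O)N3CCN(C)CC3)s2)cc1` has not yet been measured. It differs from compound 2 by hydrogen in place of phenyl on a saturated chain carbon bound to an amine nitrogen in a ring; cut one bond further out, the change reads benzyl to methyl. Going by the values given here, only one measured step bears on it, a 2.2-fold higher number from compound 1 to compound 2 (0.33 log units; beyond the scatter), a modest rise when the phenyl was pushed one bond away from the nitrogen. Taking the phenyl away altogether is expected to push the number up again, though no measured pair shows this removal itself, so the size remains uncertain. Compound 3 is therefore expected to give about 450 nM in this assay, within a range from 150 nM to 1400 nM. The expected step is a 2.9-fold higher number from compound 2 to compound 3 (0.46 log units; beyond the scatter).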

Compound 3, half-maximal effective concentration: > 5000 nM
Compound 3 was reported as a limit; the forecaster's own chance of this, stated with the estimate: 5%; middle value at least 11-fold (1.04 log units) away from the limit.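

Compound 3 is reported only as a limit, not as a number: the limit of > 5000 nM in this assay, at which 1 of the 3 values shown sits. Its steps therefore give only a lower bound, yet that bound is already well beyond what the earlier pair showed: replacing the benzyl with methyl gives an at least 32-fold higher number from compound 2 to compound 3 (1.50 log units; beyond the scatter), and replacing the phenyl with methyl gives an at least 69-fold higher number from compound 1 to compound 3 (1.84 log units; beyond the scatter), whereas moving the phenyl one bond further out gave only a 2.2-fold higher number from compound 1 to compound 2 (0.33 log units; beyond the scatter). At this place on the amine nitrogen in the ring, then, losing the phenyl altogether counts for far more in this assay than shifting it by one bond, a difference the two earlier compounds could not reveal.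

The compounds shown do not tell whether the phenyl ring itself is required or whether another group would serve at this place, such as a cyclohexyl, a pyridyl or a longer alkyl chain like butyl. They also leave open how far the number for compound 3 lies past its limit, and whether a hydrogen on that nitrogen would behave as the methyl does.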